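The compounds below may be only part of what the source reports. "The series", "measured", "known", "first", "only" and "open" are said of these compounds alone.

Compound 2, `O=C(Nc1cc(-c2ccccn2)n[nH]1)N1CCC(c2ccc(F)cc2)CC1`, carries a 4-fluorophenyl group on a saturated ring carbon of its shared core. In an ADME assay on MRC5 cells (Homo sapiens) for cytotoxicity, read by fluorescence and resazurin assay, with a stated time of 3 days (on this read-out lower numbers stand for higher toxicity in this test and higher numbers for lower toxicity in this test), compound 2 gives > 64000 nM, which is a limit of the test and not a measured number. Going by the values given here, its one measured neighbour, compound 1, `O=C(Nc1cc(-c2ccccn2)n[nH]1)N1CCC(Oc2ccccn2)CC1`, bears a (pyridin-2-yl)oxy group at the same position. In this assay compound 1 gives > 63000 nM, again a limit rather than a number. The change between them is therefore a step that the two limits leave unreadable from compound 1 to compound 2, so the step itself cannot be sized; what is known is that both sit at their limits, the limit of > 63000 nM in this assay, at which 1 of the 2 values shown sits, and (the limit of > 64000 nM in this assay, at which 1 of the 2 values shown sits).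

Compound 3, `N#Cc1ccc(OC2CCN(C(=O)Nc3cc(-c4ccccn4)n[nH]3)CC2)cc1`, differs from compound 2 by 4-cyanophenoxy in place of 4-fluorophenyl on a saturated ring carbon. Among the compounds with values here, no measured step bears on this change, since the only measured pair ends in two limits. With both measured compounds showing no toxicity up to the top of the range, compound 3 is expected to behave the same way, most likely reported as a limit too. Its expected half-maximal cytotoxic concentration is 70000 nM, with a range from 30000 nM to 200000 nM. The expected step is a step that the limit leaves unreadable from compound 2 to compound 3.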

Compound 3, half-maximal cytotoxic concentration: > 63000 nM
Compound 3: no number, only a limit; the forecaster's own chance of this, stated with the estimate: 80%; the middle value lies beyond the limit too.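

In this assay compound 3 also ends at a limit of the test and not at a number, so its steps to compound 1 and compound 2 cannot be read: the limit of > 63000 nM in this assay, at which 2 of the 3 values shown sit.

The compounds shown leave open at what concentration, if any, compound 1, compound 2 or compound 3 would harm these cells, and whether the changes between them matter.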